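The source may report more compounds than this note shows. Statements on the series, on what has been measured and on what is new or still open speak of the compounds shown alone.

Compound 1 `Cc1nc(-c2ccc(F)cc2)c(C(=O)N2CCN(c3ccc(C(=O)C(C)C)cc3)CC2)o1`: "not active" (no number reported)
Compound 2 `CCc1nc(-c2ccc(C(C)C)cc2)c(C(=O)N2CCN(c3cccc(OC)c3)CC2)o1`: 887 nM

In a functional assay on HL-60 cells (Homo sapiens) for inhibition, read by MTT assay, with a stated time of 72 h (a higher number here means a weaker inhibitor, a lower number a stronger inhibitor), compound 2 gives 887 nM. Among the compounds with values here, this is the only number available, so it cannot yet be ranked against any other value. Compound 3 `CCc1nc(-c2ccccc2F)c(C(=O)N2CCN(c3cccc(OC)c3)CC2)o1` differs from compound 2 in one place: 2-fluorophenyl in place of 4-isopropylphenyl on an aromatic carbon. It has 2-fluorophenyl in place of 4-isopropylphenyl on an aromatic carbon, next to the ring nitrogen. Within the data shown here, no measured pair shows what this swap does. The only hint is weak: compound 1, which also carries a fluorine on its phenyl group, gave "not active" (no number reported), but it differs elsewhere too. A moderate loss of strength in this assay therefore seems likelier than a gain, and the expected change is a 2.5-fold higher number from compound 2 to compound 3 (0.39 log units; beyond the scatter). For compound 3 the estimated value is 2200 nM, with an expected range of 600 nM to 9000 nM.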

Compound 3, half-maximal inhibitory concentration: 607 nM
Estimate against measurement, compound 3: 3.6-fold (0.56 log units) above; the range from low to high includes it.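

In this assay, placing 2-fluorophenyl in place of 4-isopropylphenyl, on the aromatic carbon next to the ring nitrogen, gives a 1.5-fold lower number from compound 2 to compound 3 (0.16 log units; within the scatter), so the two compounds cannot be told apart. This position therefore accepts two quite different phenyl groups, one with 9 heavy atoms and one with 7, without a change beyond the scatter, and a fluorine on the phenyl group is compatible with activity in compound 3. Nothing available explains why the swap leaves the value so little changed.

From the compounds shown here alone, only these two groups can be compared at this position, so how far this tolerance extends remains open. A phenyl group carrying an amine or a carboxylic acid, or a plain phenyl group with no substituent, could still behave differently.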